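Methyl on the outer ring: a weakly cytotoxic coumarin-pyrazole set

The source may hold more compounds than are shown below. What is called first, only, known or untested is meant among the compounds shown, and "the series" means these compounds.

Measured compounds:
Compound 1 `CCOC(=O)c1c(-c2c(Cl)c3ccccc3oc2=O)nn(-c2cccc(Cl)c2)c1C(=O)OCC`: 38000 nM
Compound 2 `CCOC(=O)c1c(-c2c(Cl)c3cc(C)ccc3oc2=O)nn(-c2cccc(Cl)c2)c1C(=O)OCC`: 128000 nM
Compound 3 `COC(=O)c1c(-c2cc3ccccc3oc2=O)nn(-c2ccccc2)c1C(=O)OC`: 28000 nM

All three were tested in a functional assay on A549 cells (Homo sapiens) for cytotoxicity, read by MTT assay, with a stated time of 48 h; on this read-out lower numbers stand for stronger inhibition and higher numbers for weaker inhibition. Compound 1 and compound 2 share one core and differ in one place, (methyl in place of hydrogen on an aromatic carbon). Their step is a 3.4-fold higher number from compound 1 to compound 2 (0.53 log units; beyond the scatter). Compound 3 has a different core; the difference between the two cores is not broken down here. Compound 3 and compound 1 give numbers that lie within the usual scatter of each other, so no order between them can be claimed.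

Compound 4 `COC(=O)c1c(-c2cc3ccccc3oc2=O)nn(-c2cccc(C)c2)c1C(=O)OC` has not yet been measured. It differs from compound 3 in one place, (methyl in place of hydrogen on an aromatic carbon). Among the measured compounds shown here, this is the same kind of change as the one from compound 1 to compound 2, but not the same: there the methyl entered on a ring that is part of a fused system of two rings, meta to a fused ring and para to a fused ring, whereas here it enters on a six-membered ring of carbon only, meta to a large group.

For the measured compounds named here, the only guide is the single measured step, which pointed toward a higher number. Because that change on a different ring gave a 3.4-fold higher number from compound 1 to compound 2 (0.53 log units; beyond the scatter), a somewhat smaller rise is expected for compound 4, estimated as a 2.0-fold higher number from compound 3 to compound 4 (0.29 log units; within the scatter). Compound 4 is therefore estimated at 55000 nM, with a likely range from 20000 nM to 150000 nM.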

Compound 4, half-maximal inhibitory concentration: 51000 nM
Estimate against measurement, compound 4: 1.1-fold (0.03 log units) above; the measured number falls inside the stated range.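

In this assay, the change from phenyl to 3-methylphenyl gives a 1.8-fold higher number from compound 3 to compound 4 (0.26 log units; within the scatter), a step that on its own cannot be told apart from no change at all. Set beside the earlier methyl step, the new step cannot be shown to differ from it: the same change on two cores in this assay, a 3.4-fold higher number (0.53 log units; beyond the scatter) from compound 1 to compound 2 and a 1.8-fold higher number (0.26 log units; within the scatter) from compound 3 to compound 4, 1.8-fold (0.27 log units) apart, within the scatter of two such steps. Among the compounds shown here, this shows that the two results are compatible with a similar effect of the methyl on both cores, but it does not show that the effect carries over, as only one of the two steps lies beyond the scatter, the methyl enters a different ring in each pair, and two pairs are too few to support a rule for the series.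

The compounds shown leave open whether a group other than methyl at this place, such as an amine, a carboxylic acid or a longer chain, would move the number clearly beyond the scatter, and in which direction. Also open, on these data alone, is what a methyl would do on the core of compound 3 at the spot it occupies in compound 2, which would compare the two cores with the methyl on the same ring.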